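A few compounds are considered here, and "the series" means these few. Any claim that something is new, unique, unknown or untested is made for them only; others in the source may bear on it.

Compound 1 `N#CCCCn1c(Cn2c(=O)n(-c3ccc(C(=O)O)cc3)c3ccncc32)cc2cc(Cl)ccc21` gives in an ADME assay on HeLa cells (Homo sapiens) for cytotoxicity, read by ATP content, with a stated time of 3 days (on this read-out lower numbers stand for higher toxicity in this test and higher numbers for lower toxicity in this test), a limit, > 50000 nM.
Compound 2 `CC1(n2c(=O)n(Cc3cc4cc(Cl)ccc4n3CCCS(C)(=O)=O)c3cnccc32)CC1` gives in this assay a limit, > 50000 nM.
Compound 3 `CS(=O)(=O)CCCn1c(Cn2c(=O)n(C3CN(S(C)(=O)=O)C3)c3ccncc32)cc2cc(Cl)ccc21` gives in this assay a limit, > 50000 nM.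

Compound 3 therefore stands at the limit of this assay, where all three measured values sit (the limit of > 50000 nM in this assay, at which 3 of the 3 values shown sit); nothing in these numbers sets it apart from the other two. Among the compounds with values here, the only measured step that changes a single group is the one from compound 2 to compound 3, which exchanged 1-methylcyclopropyl for 1-(methylsulfonyl)azetidin-3-yl on an aromatic nitrogen, and that step is a step that the two limits leave unreadable from compound 2 to compound 3: both ends are limits, so its size cannot be read.

Compound 4 `CC(C)(C)n1c(=O)n(Cc2cc3cc(Cl)ccc3n2CCCS(C)(=O)=O)c2cnccc21` differs from compound 3 in one place: tert-butyl in place of 1-(methylsulfonyl)azetidin-3-yl on an aromatic nitrogen. The step from compound 2 to compound 3 is the one that bears on this change, and since it could not be read, no direction can be taken from it. Every shown value is a limit, so the expectation for compound 4 is that it too comes out at the limit of this assay, with no step beyond the scatter. Compound 4 is thus estimated at 50000 nM, ranging from 30000 nM to 100000 nM. The step this means, from compound 3 to compound 4, is expected to be a number no higher from compound 3 to compound 4 (the limit leaves the size open).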

Compound 4, half-maximal cytotoxic concentration: > 50000 nM
Compound 4: only a limit was reported (the forecaster's own chance of this, stated with the estimate: 85%); the middle value lies on the limit itself.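

In this assay compound 4 gives > 50000 nM, which is a limit and not a number. Within the data shown here, no step from compound 2 or compound 3 to compound 4 can be read, as each has a limit at both ends. The compounds shown leave open whether tert-butyl, 1-methylcyclopropyl and 1-(methylsulfonyl)azetidin-3-yl differ at all in this assay, and at what concentration any of these compounds would become toxic: the limit of > 50000 nM in this assay, at which 4 of the 4 values shown sit.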